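The compounds below may be only part of what the source reports. "The series", "measured", "known", "first", "only" and "open" are said of these compounds alone.

Measured so far:
compound 1 `Cn1c(=O)[nH]c2ccc(OCCc3cccc(Cl)c3)cc21` — 13.7%
compound 2 `O=C1Nc2ccc(OCc3cccc(Cl)c3)cc2C1=O` — 93%

In an assay on cells for inhibition of Amine oxidase [flavin-containing] B (Homo sapiens), read by fluorescence, with stated times of 30 min and 15 min, tested at 1 uM (a higher number here means more inhibition at the concentration tested (going by the name of the read-out), a lower number less inhibition), compound 1 gives 13.7%, the lowest of the two numbers measured. Among the compounds with values here, compound 2 gives 93% in this assay, a value far above that of compound 1, with the gap well beyond the usual scatter; no single-point step links these two compounds, so only the two values themselves can be compared.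

Compound 3 `Cn1c(=O)[nH]c2ccc(OCCc3ccccc3)cc21` has not yet been measured. It differs from compound 1 in one place: hydrogen in place of chloro on an aromatic carbon. Within the data shown here, no step between measured compounds matches this change, so there is no measured basis for its size. The account expects only a small step in this assay, if anything downward, and most likely within the scatter. This corresponds to an expected step of a number 3.7 percentage points lower from compound 1 to compound 3 (within the scatter) in this assay. Compound 3 is therefore estimated at 10% in this assay, with an expected range from 0% to 25%.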

Compound 3, a percentage reported as inhibition, at one concentration (the size of the read-out at that concentration, not a potency): "not active" (no number reported)
No number was reported for compound 3; no gap can be computed for the estimate.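

Within the data shown here, compound 3 is reported as not active in this assay, without a number, so no step from compound 1 to compound 3 can be read. The compounds shown leave open how large the effect of the 3-chlorophenyl to phenyl change is. No supporting evidence bears on this result.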